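Swapping the acid-bearing aryl ring on a lactam core

The source may hold more compounds than are shown below. What is called first, only, known or untested is meant among the compounds shown, and "the series" means these compounds.

Measured compounds:
- Compound 1, `O=C(O)c1cc(-c2cccc(COc3ccc4c(=O)n(C5CC5)sc4c3)c2)ccc1Cl`: 70.6%
- Compound 2, `COc1ccc(-c2cccc(COc3ccc4c(c3)CN(C3CCCC3)C4=O)c2)cc1C(=O)O`: 78%
- Compound 3, `CN(C)C(=O)c1cc(-c2cccc(COc3ccc4c(=O)n(C5CCCC5)sc4c3)c2)ccc1Cl`: 54.8%

All three were tested in an assay on HEK293 cells for positive allosteric modulation of metabotropic glutamate receptor 2 (Rattus norvegicus), read by thallium flux; on this read-out higher numbers stand for larger maximal responses and lower numbers for smaller maximal responses. Compound 2 gives the largest of the three numbers; compound 1 sits within the usual scatter of it, so no order between those two can be claimed, while compound 3 lies beyond the scatter and is clearly lower.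

Compound 4, `O=C(O)c1ccc(Cl)c(-c2cccc(COc3ccc4c(c3)CN(C3CCCC3)C4=O)c2)c1`, has not yet been measured. It keeps the core of compound 2 and changes only the acid-bearing aryl group: 5-carboxy-2-chlorophenyl in place of 3-carboxy-4-methoxyphenyl on an aromatic carbon. A carboxylic acid remains, a methoxy group is lost and a chlorine is gained, and the acid now sits in a different spot on that ring.

Within the data shown here, no measured pair differs in exactly this way, so no direct step can be read off. Compound 1, which also carries a chlorine and a carboxylic acid on this ring, though on a different core, gives 70.6%, close to compound 2. The expected step of a number 6 percentage points lower from compound 2 to compound 4 (within the scatter) is therefore small, if anything slightly downward, and within the scatter. Compound 4 is expected to give about 72%, in a range from 55% to 90%.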

Compound 4, largest response reached (reported as percent of maximum), in percent of the reference or control that the assay uses: 93.9%
Beside the measured number, compound 4's estimate is 21.9 percentage points below it; the whole stated range lies below it.
By their numbers in this assay, from the lowest: compound 3; then compounds 1 and 2 (each within the scatter of the next); then compound 4.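

In this assay, putting 5-carboxy-2-chlorophenyl in place of 3-carboxy-4-methoxyphenyl on the shared core gives a number 15.9 percentage points higher from compound 2 to compound 4 (beyond the scatter), so the maximal response depends on what this aryl group carries, even though both versions keep a carboxylic acid. This aromatic carbon, meta to a large group, is therefore not a spot where such a swap passes unnoticed, and here the swap raises the number rather than lowering it. Nothing in the data on hand accounts for this rise.

The change loses a methoxy group, gains a chlorine and moves the acid all at once, so the compounds shown cannot tell which of these three differences carries the step. Going by these compounds, it also stays open whether a fluorine or a methyl group in place of the chlorine would give a similar maximal response, and whether a tetrazole could stand in for the carboxylic acid on this ring.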